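The source may report more compounds than this note shows. Statements on the series, on what has been measured and on what is new or still open speak of the compounds shown alone.

Compound 1 `CCCCCCCCCCn1c(=O)n(C2OC(CO)[C@@H](O)[C@H]2O)c2nc(N)nc(O)c21` was tested in a functional assay on the whole organism with Mus musculus as the target (a higher number here means a larger maximal response, a lower number a smaller maximal response), and gave 0%, the lowest of the three numbers recorded. Compound 3 `C=CCn1c(=O)n(CCCC)c2nc(N)nc(O)c21` gave 36% in this assay, and compound 2 `C=CCSc1nc2c(O)nc(N)nc2n1C1OC(CO)[C@@H](O)[C@H]1O` gave 57%, both standing above compound 1 by more than the scatter. Compound 4 `Nc1nc(O)c2c(n1)n(C1OC(CO)[C@@H](O)[C@H]1O)c(=O)n2C/C=C/c1ccccc1` has not yet been measured; it differs from compound 1 in one place: 2-phenylethenyl in place of nonyl on a saturated chain carbon bound to an aromatic nitrogen. Within the data shown here, no pair of measured compounds differs in a single place, so the size of this change cannot be read from a recorded step. Because compound 3 reaches 36% with a different group on the shared core, a moderate rise is expected, estimated as a number 25 percentage points higher from compound 1 to compound 4 (beyond the scatter) in this assay. Compound 4 is accordingly expected to give 25%, within a range from 0% to 60%.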

Compound 4, largest response reached (reported as maximal response), in percent of the reference or control that the assay uses: 5%
Compound 4: middle estimate off by 20 percentage points, on the high side; low and high end bracket the measured number.
By their numbers in this assay, from the lowest: compounds 1 and 4 (each within the scatter of the next); then compound 3; then compound 2.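

In this assay, 2-phenylethenyl in place of nonyl on a saturated chain carbon bound to an aromatic nitrogen gives a number 5 percentage points higher from compound 1 to compound 4 (within the scatter) and so stays within the scatter. This first single-place step at the position shows that exchanging the all-carbon chain for a group with one six-membered aromatic ring and one double bond does not separate the two compounds. Nothing at hand accounts for this result. Going by these compounds, whether a chain ending in an amine or a carboxylic acid at this position would move the number beyond the scatter stays open.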